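The source may report more compounds than this note shows. Statements on the series, on what has been measured and on what is new or still open speak of the compounds shown alone.

Three measured compounds share one core and differ only in the group on the aromatic ring that carries the sulfonamide nitrogen. Compound 1 `C[C@@H]1CN(c2cc(NS(=O)(=O)c3ccc(-c4ccccn4)s3)ccc2C#N)C[C@H](C)N1` carries a nitrile there and gives 0.9 in a functional assay for agonist activity at growth hormone secretagogue receptor type 1 (Homo sapiens), read by FLIPR; on this read-out higher numbers stand for larger maximal responses and lower numbers for smaller maximal responses. Compound 2 `COc1ccc(N2C[C@@H](C)N[C@@H](C)C2)cc1NS(=O)(=O)c1ccc(-c2ccccn2)s1` carries a methoxy and gives 1.1. Compound 3 `CCOc1ccc(N2C[C@@H](C)N[C@@H](C)C2)cc1NS(=O)(=O)c1ccc(-c2ccccn2)s1` carries an ethoxy and gives 0.8. Compound 3 thus sits at the low end of the three numbers: its gap to compound 1 lies within the scatter, while the step a number 0.30 lower from compound 2 to compound 3 (beyond the scatter) is the only one among these compounds that lies beyond it.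

Compound 4 `CC(=O)c1ccc(N2C[C@@H](C)N[C@@H](C)C2)cc1NS(=O)(=O)c1ccc(-c2ccccn2)s1` differs from compound 3 by acetyl in place of ethoxy on an aromatic carbon. Within the data shown here, no measured step swaps an ethoxy for an acetyl; the only measured step, methyl in place of hydrogen on a saturated chain carbon bound to an oxygen on an aromatic ring, was a modest change of a different kind, and the nitrile of compound 1 gives a number within the scatter of compound 3. Among the measured compounds shown here, with no step of the same kind to lean on, no change beyond the scatter is expected. The expected step is no change at the digits printed from compound 3 to compound 4 (within the scatter). Compound 4 is therefore estimated at 0.8, with a range from 0.5 to 1.1.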

Compound 4, intrinsic activity: the largest response reached, as a fraction of the reference agonist's: 0.9
Compound 4: middle estimate off by 0.10, on the low side; measured number inside the range.
By their numbers in this assay, from the lowest: compounds 3, 1 and 4 (each within the scatter of the next); then compound 2.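

Acetyl and ethoxy have the same count of heavy atoms and hydrogen-bond acceptors, but acetyl adds a double bond outside the aromatic rings. On this aromatic carbon, that swap gives only a number 0.10 higher from compound 3 to compound 4 (within the scatter) in this assay, so this pair shows that a group joined to the ring through a carbonyl carbon can stand in for one joined through oxygen without a change beyond the usual scatter. Methoxy, by contrast, stays apart from acetyl, with a number 0.20 lower from compound 2 to compound 4 (beyond the scatter), so an oxygen link to the ring does not by itself set the number, and no information on why these groups differ is available.

The shared core therefore still leaves open how a plain methyl, joined through carbon and smaller than acetyl, would compare with methoxy on this same aromatic carbon. On these data alone, it is also open how an amine, a carboxylic acid or a longer chain such as propoxy would read there, and whether any of these would match or pass the value of compound 2 at 1.1.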